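The source may report more compounds than this note shows. Statements on the series, on what has been measured and on what is new or still open speak of the compounds shown alone.

Working notes on the series. The shared core carries a variable aryl group on the carbon that is ortho to the large aryloxy group and para to the (4-cyanophenyl)amino group. Compound 1 `Cc1cc(C)cc(-c2cnc(Nc3ccc(C#N)cc3)nc2Oc2c(C)cc(C#N)cc2C)c1` gives 39000 nM in an ADME assay on MT4 cells (Homo sapiens) for cytotoxicity, read by MTT assay, with a stated time of 5 days; a higher number here means that more compound is tolerated, a lower number that less compound is tolerated. Compound 2 `Cc1cc(C#N)cc(C)c1Oc1nc(Nc2ccc(C#N)cc2)ncc1-c1ccc2ccccc2c1` gives 8460 nM in this assay, a drop of a 4.6-fold lower number from compound 1 to compound 2 (0.66 log units; beyond the scatter). Compound 3 `Cc1cc(C#N)cc(C)c1Oc1nc(Nc2ccc(C#N)cc2)ncc1-c1ccco1` reaches only the assay limit, > 306000 nM, in this assay; no number is known for it, so it stands at the top of the values shown, consistent with the limit of > 306000 nM in this assay, at which 1 of the 3 values shown sits. The steps into compound 3 are an at least 7.8-fold higher number from compound 1 to compound 3 (0.89 log units; beyond the scatter) and an at least 36-fold higher number from compound 2 to compound 3 (1.55 log units; beyond the scatter).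

Compound 4 `COc1ccc(-c2cnc(Nc3ccc(C#N)cc3)nc2Oc2c(C)cc(C#N)cc2C)cc1` differs from compound 3 by 4-methoxyphenyl in place of furan-2-yl on an aromatic carbon. Both measured steps that end at compound 3 replace a six-membered carbon-only ring by furan-2-yl and raise the number beyond the scatter; reversing such a change is therefore expected to lower the number. Compound 4 is expected to give 40000 nM in this assay, within 12000 nM to 150000 nM, a step of an at least 7.6-fold lower number from compound 3 to compound 4 (0.88 log units; beyond the scatter), close to compound 1 with its 39000 nM rather than to compound 2 with its 8460 nM.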

Compound 4, half-maximal cytotoxic concentration: > 279000 nM
Compound 4 ended at the assay's limit; the forecaster's own chance of this, stated with the estimate: 20%; middle value at least 6.9-fold (0.84 log units) away from the limit.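

Compound 4 stands at a limit of the assay, not at a number: the limit of > 279000 nM in this assay, at which 1 of the 4 values shown sits. A six-membered aromatic ring of carbon only at this position therefore does not by itself bring the lower numbers of compound 1 and compound 2, as the steps show: an at least 32-fold higher number from compound 2 to compound 4 (1.51 log units; beyond the scatter) and an at least 7.1-fold higher number from compound 1 to compound 4 (0.85 log units; beyond the scatter). The step between compound 3 and compound 4 joins two limits and cannot be read, so furan-2-yl and 4-methoxyphenyl cannot be ordered here.

The compounds shown do not settle whether the gap between compound 1 and compound 4 goes with the methoxy group or with the methyl groups of 3,5-dimethylphenyl. Also open, as far as these compounds go, is where an unsubstituted phenyl, or a phenyl carrying an amine or a carboxylic acid, would stand in this assay.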